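Replacing methoxy by benzylamino on the shared core

The source may hold more compounds than are shown below. What is called first, only, known or untested is meant among the compounds shown, and "the series" means these compounds.

Compound 3 `COc1nc(NCCCN(C)C)c2sc(-c3ccc(C(F)(F)F)cc3)cc2n1` sits at the floor of the numbers shown: in a physicochemical assay for solubility, in phosphate buffer, at pH 6.5 (on this read-out higher numbers stand for higher solubility and lower numbers for lower solubility), compound 3 gives < 5 ug/mL, which is a limit of the assay rather than a number. Compound 1 `CN(C)CCCNc1nc(N)nc2cc(-c3ccc(C(F)(F)F)cc3)sc12` gives 148 ug/mL in this assay, and compound 2 `CN(C)CCCNc1ncnc2cc(-c3ccc(C(F)(F)F)cc3)sc12` gives 205 ug/mL. The steps of an at least 29-fold lower number from compound 1 to compound 3 (1.47 log units; beyond the scatter) and an at least 41-fold lower number from compound 2 to compound 3 (1.61 log units; beyond the scatter) are both large, while a 1.4-fold higher number from compound 1 to compound 2 (0.14 log units; within the scatter) is not; the limit of < 5 ug/mL in this assay, at which 1 of the 3 values shown sits, marks where compound 3 lies. Compound 4 `CN(C)CCCNc1nc(NCc2ccccc2)nc2cc(-c3ccc(C(F)(F)F)cc3)sc12` differs from compound 3 in that (benzylamino in place of methoxy on an aromatic carbon), on an aromatic carbon between two ring nitrogen atoms. No measured step exchanges methoxy for benzylamino, so the two large steps into compound 3 give only a floor to reason from. The account expects a small step of an at least 1.6-fold higher number from compound 3 to compound 4 (0.20 log units; that floor lies within the scatter), leaving compound 4 near the limit, with a real chance that this assay again reports only a limit. The estimate for compound 4 in this assay is 8 ug/mL, within a range from 2 ug/mL to 40 ug/mL.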

Compound 4, solubility: < 5 ug/mL
Compound 4: only a limit was reported; the forecaster's own chance of this, stated with the estimate: 45%; middle value at least 1.6-fold (0.20 log units) from the limit.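

In this assay, the large drop at the aromatic carbon between two ring nitrogen atoms is no longer tied to methoxy: benzylamino in place of hydrogen there gives an at least 41-fold lower number from compound 2 to compound 4 (1.61 log units; beyond the scatter) and matches what methoxy did. Benzyl on the nitrogen of the amino group gives an at least 29-fold lower number from compound 1 to compound 4 (1.47 log units; beyond the scatter) even though a nitrogen stays attached to this carbon, so the amino nitrogen alone does not hold the value of compound 1. Methoxy and benzylamino at this carbon now end at the same limit: the limit of < 5 ug/mL in this assay, at which 2 of the 4 values shown sit.

The step from compound 3 to compound 4 cannot be read: both values are limits. On these data alone, whether methylamino or dimethylamino at this carbon stays with compound 1 or falls to the limit remains open.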